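Replacing the methoxypyridine of compound 1 with a pyrimidine

A few compounds are considered here, and "the series" means these few. Any claim that something is new, unique, unknown or untested is made for them only; others in the source may bear on it.

Compound 1 `COc1ccnc(-c2cc(Cl)ccc2NS(=O)(=O)c2ccc(C(C)(C)C)cc2)c1` stands at the weak end of the two measured compounds: in a functional assay on isolated protein for antagonist activity at C-C chemokine receptor type 9 (Homo sapiens), read by calcium flux, with a stated time of 10 min (a higher number here means a weaker inhibitor, a lower number a stronger inhibitor), compound 1 gives 2500 nM, the highest of the two numbers, whereas compound 2 `CC(C)(C)c1ccc(S(=O)(=O)Nc2ccc(Cl)cc2-c2nccc(CO)c2O)cc1` gives 8.7 nM. Within the data shown here, the only measured step, a 290-fold lower number from compound 1 to compound 2 (2.46 log units; beyond the scatter), is large. Compound 3 `CNc1ncc(O)c(-c2cc(Cl)ccc2NS(=O)(=O)c2ccc(C(C)(C)C)cc2)n1` differs from compound 1 by a group of 9 heavy atoms (5 carbon, 3 nitrogen, 1 oxygen; one six-membered aromatic ring with 2 hetero atoms) in place of a group of 8 heavy atoms (6 carbon, 1 nitrogen, 1 oxygen; one six-membered aromatic ring with 1 hetero atom), on an aromatic carbon. Among the measured compounds shown here, the step from compound 1 to compound 2 is the only one bearing on this change; it removed the same 4-methoxypyridin-2-yl group, ortho to a large group and meta to a chloro group, and brought in a ring that, like the entering group of compound 3, carries hydrogen-bond donors where the leaving group has none. The entering ring of compound 3 is not that of compound 2, so a smaller but still sizeable gain is expected, a 50-fold lower number from compound 1 to compound 3 (1.70 log units; beyond the scatter). In this assay compound 3 is estimated at 50 nM, with a range from 8 nM to 400 nM.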

Compound 3, half-maximal inhibitory concentration: 27 nM
Compound 3: the middle estimate sits 1.9-fold (0.27 log units) above what was measured, and the stated range covers the measured number.
By their numbers in this assay, from the lowest: compound 2; then compound 3; then compound 1.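

The change in this assay gives a 93-fold lower number from compound 1 to compound 3 (1.97 log units; beyond the scatter) and so shows that the large gain at this position, on an aromatic carbon ortho to a large group and meta to a chloro group, is not confined to the ring of compound 2. The two entering rings are still not interchangeable, since the step between them is modest but beyond the scatter (a 3.1-fold higher number from compound 2 to compound 3 (0.49 log units; beyond the scatter)). Across these three compounds, the two lower numbers belong to the rings with hydrogen-bond donors, which the 4-methoxypyridin-2-yl group lacks, but no measurement available here explains the gain.

Which part of the entering ring of compound 3 carries the gain remains open, whether the hydroxyl, the methylamino group or the second ring nitrogen. A methoxy group in place of the hydroxyl, or a dimethylamino group in place of the methylamino group, would help separate these contributions.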